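The source may hold more compounds than are shown below. What is called first, only, known or untested is meant among the compounds shown, and "the series" means these compounds.

Measured so far:
- compound 1, `C=CC(=O)Nc1cccc(-n2c(-c3nc(-c4cnn(C5CCN(C)CC5)c4)cnc3N)nc3ccncc32)c1`, which in an ADME assay on liver for metabolic stability, with Liver microsome (Homo sapiens) as the target, using microsomes (a lower number here means slower removal, a higher number faster removal of the compound), gives 68 mL.min-1.g-1
- compound 2, `C=CC(=O)Nc1cccc(-n2c(-c3nc(-c4cnn(C)c4)cnc3N)nc3ccccc32)c1`, which in this assay gives 24 mL.min-1.g-1

Compound 2 has the lower of the two numbers in this assay; the gap to compound 1 is beyond the usual scatter of the assay, so compound 2 is removed more slowly than compound 1 in this setting. Among the measured compounds shown here, the two compounds differ in more than one place, so no single step between them is set out.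

The compound that follows, compound 3, `C=CC(=O)Nc1cccc(-n2c(-c3nc(-c4cnn(C5CCN(CC)CC5)c4)cnc3N)nc3ccccc32)c1`, has not yet been measured in this assay. It differs from compound 2 in one place: 1-ethylpiperidin-4-yl in place of methyl on an aromatic nitrogen. Compound 1, which also carries a piperidin-4-yl ring on that nitrogen, gives 68 mL.min-1.g-1 in this assay, a higher number than compound 2, though its fused core also differs. On that basis compound 3 is expected to move upward from compound 2 by a step of about a 2.1-fold higher number from compound 2 to compound 3 (0.32 log units; beyond the scatter), most likely beyond the scatter. The value expected for compound 3 in this assay is 50 mL.min-1.g-1, within a range from 25 mL.min-1.g-1 to 110 mL.min-1.g-1.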

Compound 3, intrinsic clearance in microsomes: 197 mL.min-1.g-1
Compound 3: the middle estimate sits 3.9-fold (0.60 log units) below what was measured; measured number above the stated range.
By their numbers in this assay, from the lowest: compound 2; then compound 1; then compound 3.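

Among the compounds shown here, the pair of compound 2 and compound 3 gives the first reading of this position on its own, since the two earlier compounds differed in more than one place. With the shared core held constant, in this assay the exchange of methyl for 1-ethylpiperidin-4-yl on the aromatic nitrogen brings an 8.2-fold higher number from compound 2 to compound 3 (0.91 log units; beyond the scatter), so a change at this one place is enough to move the number a long way towards faster removal. No measurement shown here gives a reason for this step.

The exchange replaces a methyl with a whole ring that carries its own ethyl group, so the compounds shown leave open whether the ring itself or the ethyl on its nitrogen accounts for the step, and compound 1, with its different core, cannot settle that. On the shared core of compound 2 and compound 3, a piperidin-4-yl ring with only hydrogen on its nitrogen, or a tetrahydropyran-4-yl ring with oxygen in place of that nitrogen, would separate these two parts of the change.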